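A few compounds are considered here, and "the series" means these few. Any claim that something is new, unique, unknown or untested is made for them only; others in the source may bear on it.

Working notes on the series. Compound 1 `CCOc1cc(=O)n(CCCO)c2c1CC(CC=C(C)C)C(C)(C)C2` is the parent; in a functional assay on PANC-1 cells (Homo sapiens) for inhibition, read by MTT assay, with a stated time of 24 h, tested at 10 uM (a higher number here means more inhibition at the concentration tested (going by the name of the read-out), a lower number less inhibition), compound 1 gives 16.6%. Compound 2 `CC(C)=CCC1Cc2c(OCCCNS(=O)(=O)c3ccc(Cl)cc3)cc(=O)n(CCCO)c2CC1(C)C` carries (((4-chlorophenyl)sulfonyl)amino)methyl in place of hydrogen on a saturated chain carbon, two bonds along the chain from an oxygen on an aromatic ring; in this assay compound 2 gives 9.8%. The step of a number 6.8 percentage points lower from compound 1 to compound 2 (within the scatter) is within the scatter, so on the two numbers available compound 2 stands alongside compound 1 rather than apart from it.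

Compound 3 `CC(C)=CCC1Cc2c(OCCCNS(=O)(=O)c3ccc(Br)cc3)cc(=O)n(CCCO)c2CC1(C)C` differs from compound 2 by bromo in place of chloro on an aromatic carbon. Going by the values given here, no measured step exchanges one halogen for another; the sole measured step, a number 6.8 percentage points lower from compound 1 to compound 2 (within the scatter), concerns a far larger group and is itself within the scatter. For a number 0.2 percentage points higher from compound 2 to compound 3 (within the scatter) no movement beyond the scatter is therefore expected. Compound 3 is estimated at 10% in this assay, with a range from 0% to 22%.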

Compound 3, a percentage reported as inhibition, at one concentration (the size of the read-out at that concentration, not a potency): 3.7%
Estimate against measurement, compound 3: 6.3 percentage points above; the range from low to high includes it.
By their numbers in this assay, from the lowest: compounds 3, 2 and 1 (each within the scatter of the next, the first and the last beyond it).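

In this assay, bromo in place of chloro on the aromatic carbon gives a number 6.1 percentage points lower from compound 2 to compound 3 (within the scatter), so the halogen at this place does not separate compound 2 from compound 3. Going by these compounds alone, measured against the parent, the bromo-bearing side chain gives a number 12.9 percentage points lower from compound 1 to compound 3 (beyond the scatter), the first step to pass beyond the scatter, though only modestly, while its chloro counterpart gives a number 6.8 percentage points lower from compound 1 to compound 2 (within the scatter); as compound 2 and compound 3 stand within the scatter of each other, this is slim support for any real difference between the two halogens. No measured information accounts for either step.

Going by these compounds, whether a methoxy group, an amine or a carboxylic acid at that aromatic carbon would move the number beyond the scatter remains open. Also open, on these data alone, is whether an amide in place of the sulfonyl link would hold the step from the parent.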